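Isopropyl for Fluorophenyl in a Weakly Cytotoxic Series

This account rests on a few compounds, and the source may have more. Where it says the series, first, only, none or still open, it means among the compounds named here.

Compound 1, `Cc1ccc2c(NCc3ccc(NC(=O)C4CCN(Cc5ccccc5)CC4)cc3)nc(N3CCCCCC3)nc2c1`, in a functional assay on SV5A8 cells (Homo sapiens) for cytotoxicity (a higher number here means a weaker inhibitor, a lower number a stronger inhibitor), gives > 6880 nM, which is a limit of the assay.
Compound 2, `Cc1ccc2c(NCc3ccc(NC(=O)C4CCN(Cc5ccccc5)CC4)cc3)nc(N3CCNC(CCO)C3)nc2c1`, gives in this assay the value > 8420 nM, again only a limit.
Compound 3, `Cc1ccc2c(NCc3ccc(NC(=O)C4CCN(Cc5ccccc5F)CC4)cc3)nc(N(C)C)nc2c1`, gives in this assay the value > 6670 nM, also a limit and not a number.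

Compound 3 therefore stands where all three measured compounds stand: at a limit of the assay, with no real number for any of them (the limit of > 6670 nM in this assay, at which 1 of the 3 values shown sits, (the limit of > 6880 nM in this assay, at which 1 of the 3 values shown sits), (the limit of > 8420 nM in this assay, at which 1 of the 3 values shown sits)). Going by the values given here, the one measured step, a step that the two limits leave unreadable from compound 1 to compound 2, gives no readable size. Compound 4, `Cc1ccc2c(NCc3ccc(NC(=O)C4CCN(CC(C)C)CC4)cc3)nc(N(C)C)nc2c1`, differs from compound 3 by isopropyl in place of 2-fluorophenyl on a saturated chain carbon bound to an amine nitrogen in a ring. Among the compounds with values here, none of the measured steps touches this part of the molecule, so none bears on it, and there is no basis for expecting a shift in either direction beyond the scatter. The step from compound 3 to compound 4 is expected to be a step that the limit leaves unreadable from compound 3 to compound 4, which most likely means another limit. Compound 4 is estimated at 10000 nM, within 4000 nM to 30000 nM.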

Compound 4, half-maximal inhibitory concentration: > 10500 nM
Compound 4 was reported as a limit; the forecaster's own chance of this, stated with the estimate: 80%; middle value at least 1.0-fold (0.02 log units) from the limit.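

Compound 3 and compound 4 both give only limits, not numbers, so the step between them, isopropyl in place of 2-fluorophenyl, cannot be read. The compounds shown leave open what real number any of them would give in this assay, and whether any of these changes shifts it.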